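Series notes: 3-hydroxypropoxy to 2-hydroxyethoxy

This account rests on a few compounds, and the source may have more. Where it says the series, first, only, none or still open, it means among the compounds named here.

Measured so far in a functional assay on HeLa cells (Homo sapiens) for antiproliferative activity; a lower number here means a stronger inhibitor, a higher number a weaker inhibitor:
- compound 1 `CO/N=C/c1c(N)ncnc1Oc1ccc2cccnc2c1` gives 1820 nM
- compound 2 `Cc1cc2c(F)c(Oc3ncnc(N)c3/C=N/OCCCO)ccc2[nH]1` gives 362 nM
- compound 3 `CO/N=C/c1c(N)ncnc1Oc1ccc2[nH]cc(C)c2c1` gives 306 nM

Compound 2 holds the second highest of the three numbers. Its nearest neighbour is compound 3, whose number is lower only within the scatter, so no order between compound 2 and compound 3 can be read. The furthest is compound 1, whose number is higher beyond the scatter.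

Compound 4 `Cc1cc2c(F)c(Oc3ncnc(N)c3/C=N/OCCO)ccc2[nH]1` differs from compound 2 in one place: hydroxy in place of hydroxymethyl on a saturated chain carbon, two bonds along the chain from an oxygen, that is, 3-hydroxypropoxy becomes 2-hydroxyethoxy. The change keeps the donor and acceptor count and removes one chain carbon. With no measured step of this kind in the set, the step of a 1.0-fold lower number from compound 2 to compound 4 (0.01 log units; within the scatter) is expected to stay within the scatter, in either direction. Compound 4 is therefore expected to give about 350 nM, in the range 150 nM to 800 nM.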

Compound 4, half-maximal inhibitory concentration: 406 nM
For compound 4 the middle estimate is 1.2-fold (0.06 log units) below the measured one; measured number inside the range.
By their numbers in this assay, from the lowest: compounds 3, 2 and 4 (each within the scatter of the next); then compound 1.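

Shortening 3-hydroxypropoxy to 2-hydroxyethoxy gives a 1.1-fold higher number from compound 2 to compound 4 (0.05 log units; within the scatter) in this assay and so provides the first one-place comparison in the series. At this position, removing one chain carbon while keeping the terminal hydroxy produces no change that can be read. No supporting measurement bears on why this step is so small.

Still open, on these data alone, is whether the same holds for a longer chain such as 4-hydroxybutoxy. As far as these compounds go, it is also open whether a terminal amine or carboxylic acid in place of the hydroxy would leave the number within the scatter.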